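The compounds below may be only part of what the source reports. "The series", "measured", "known", "first", "only" and "open" are said of these compounds alone.

Compound 1 `CCc1cccc2c(O)c(-c3occ(C)c3C(=O)O)ccc12` gives 9.1 ug/mL in a functional assay on KB cells (Homo sapiens) for cytotoxicity, read by MTT assay, with a stated time of 72 h; a higher number here means that more compound is needed for the effect, a lower number that less compound is needed. Compound 2 `CCOc1c(-c2occ(C)c2C(=O)O)ccc2c(CC)cccc12` reaches only the limit of the test, recorded as > 10 ug/mL in this assay. Compound 3 `CCc1cccc2c(OC)c(-c3occ(C)c3CBr)ccc12` likewise reaches only a limit, > 10 ug/mL in this assay. So compound 2 stands at the limit, the position described by the limit of > 10 ug/mL in this assay, at which 2 of the 3 values shown sit; the single measured step, an at least 1.0-fold higher number from compound 1 to compound 2 (0.04 log units; that floor lies within the scatter), concerns a different place on the molecule and says little about what follows. Compound 4 `CCOc1c(-c2occ(C)c2COC)ccc2c(CC)cccc12` differs from compound 2 by methoxymethyl in place of carboxy on an aromatic carbon. For the measured compounds named here, no measured step bears on this change, so no direction is expected beyond the scatter. Compound 4 is therefore expected to sit near the limit, estimated at 15 ug/mL with a range of 6 ug/mL to 40 ug/mL, meaning an expected step that the limit leaves unreadable from compound 2 to compound 4.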

Compound 4, concentration for half-maximal effect: > 10 ug/mL
Compound 4: only a limit was reported (the forecaster's own chance of this, stated with the estimate: 70%); the middle value does not contradict the limit.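

Compound 2 and compound 4 both reach only a limit in this assay, so no step between them can be read: the limit of > 10 ug/mL in this assay, at which 3 of the 4 values shown sit.

The compounds shown leave open how replacing carboxy with methoxymethyl changes cytotoxicity, since neither compound has a number beyond its limit.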